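Carbamoyl chain swap to 4-fluoropiperidinyl on quinazoline urea

The compounds below may be only part of what the source reports. "The series", "measured", "known", "first", "only" and "open" are said of these compounds alone.

Compound 1, `CS(=O)(=O)CCNC(=O)Nc1cc2c(Nc3ccc(F)c(Cl)c3)ncnc2cc1O[C@H]1CCOC1`, gives 1570 nM in a functional assay on A-431 cells (Homo sapiens) for antiproliferative activity, read by sulforhodamine B assay, with a stated time of 72 h; on this read-out lower numbers stand for stronger inhibition and higher numbers for weaker inhibition.
Compound 2, `O=C(NCCN1CCCC1)Nc1cc2c(Nc3ccc(F)c(Cl)c3)ncnc2cc1O[C@H]1CCOC1`, gives 247 nM in this assay.
Compound 3, `CN(C)CCN(C)C(=O)Nc1cc2c(Nc3ccc(F)c(Cl)c3)ncnc2cc1O[C@H]1CCOC1`, gives 450 nM in this assay.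

Compound 3 stands second highest of the three numbers in this assay; its nearest neighbour is compound 2, with a 1.8-fold higher number from compound 2 to compound 3 (0.26 log units; within the scatter), and its furthest is compound 1, with a 3.5-fold lower number from compound 1 to compound 3 (0.54 log units; beyond the scatter). Compound 4, `O=C(Nc1cc2c(Nc3ccc(F)c(Cl)c3)ncnc2cc1O[C@H]1CCOC1)N1CCC(F)CC1`, differs from compound 3 in one place: 4-fluoropiperidin-1-yl in place of (2-(dimethylamino)ethyl)(methyl)amino on a carbonyl carbon. The measured steps that bear on this change are those that alter the same terminal group on the carbonyl carbon: a 6.4-fold lower number from compound 1 to compound 2 (0.80 log units; beyond the scatter) and a 3.5-fold lower number from compound 1 to compound 3 (0.54 log units; beyond the scatter), both modest and both beyond the scatter. Compound 4 carries neither the methylsulfonyl group of compound 1 nor the pyrrolidin-1-yl or dimethylamino groups of compounds 2 and 3, so the measured steps cover only part of the change. On that basis a modest step upward is expected, a 2.0-fold higher number from compound 3 to compound 4 (0.30 log units; within the scatter), landing compound 4 between compound 3 and compound 1. Compound 4 is therefore estimated at 900 nM in this assay, with a range from 300 nM to 2700 nM.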

Compound 4, half-maximal inhibitory concentration: 3040 nM
Beside the measured number, compound 4's estimate is 3.4-fold (0.53 log units) below it, and the stated range ends below it.
By their numbers in this assay, from the lowest: compounds 2 and 3 (each within the scatter of the next); then compounds 1 and 4 (each within the scatter of the next).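

At this carbonyl carbon, the 4-fluoropiperidin-1-yl ring in place of the open (2-(dimethylamino)ethyl)(methyl)amino chain weakens the result in this assay (a 6.8-fold higher number from compound 3 to compound 4 (0.83 log units; beyond the scatter)), and the step from the (2-(pyrrolidin-1-yl)ethyl)amino chain is the largest shown here (a 12-fold higher number from compound 2 to compound 4 (1.09 log units; beyond the scatter)). Against the methylsulfonyl chain the ring makes no difference beyond the scatter (a 1.9-fold higher number from compound 1 to compound 4 (0.29 log units; within the scatter)), so the group on this carbon now divides the four compounds into two sets: compound 2 and compound 3, with a pyrrolidin-1-yl or dimethylamino chain end, read low, while compound 1 and compound 4, which carry neither, read high. Nothing measured here accounts for this split. The compounds shown leave open whether the fluorine plays any part, as a plain piperidin-1-yl would show. They also leave open how a 4-fluoropiperidin-1-yl held at the end of an ethyl chain would read.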